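The source may hold more compounds than are shown below. What is called first, only, known or untested is meant among the compounds shown, and "the series" means these compounds.

Of the compounds shown here, three built on one shared core have been tested for how strongly they slow the growth of breast cancer cells, in a functional assay on MCF7 cells (Homo sapiens) for antiproliferative activity, read by MTT assay, with a stated time of 48 h; on this read-out lower numbers stand for stronger inhibition and higher numbers for weaker inhibition. Compound 1 `Cc1ccc(-c2nc3ccc(Cl)cc3c(=O)[nH]2)cc1` gives 4.98 ug/mL. Compound 2 `Cc1ccc(-c2nc(NN)c3cc(Cl)ccc3n2)cc1` gives 3.76 ug/mL. Compound 3 `Cc1ccc(-c2nc(NOC(=O)c3ccccc3)c3cc(Cl)ccc3n2)cc1` gives 5.59 ug/mL. Among the measured compounds shown here, the only single-point step among them is a 1.5-fold higher number from compound 2 to compound 3 (0.17 log units; within the scatter), a change of benzoyloxy in place of amino on a nitrogen on an aromatic ring. Compound 2 thus holds the lowest of the three numbers, but the gaps to compound 1 and to compound 3 are both inside the usual scatter, so nothing separates them with confidence.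

Compound 4 `Cc1ccc(-c2nc(SCC#N)c3cc(Cl)ccc3n2)cc1` is the next compound, differing from compound 2 by (cyanomethyl)sulfanyl in place of aminoamino on an aromatic carbon. For the measured compounds named here, the one measured step that touches this same position, from compound 2 to compound 3, altered the group hanging on that carbon without a shift beyond the scatter; here the whole nitrogen-based group gives way to a sulfur-based one, a larger change, but the only precedent points to little movement. Compound 4 is therefore expected near 5 ug/mL, within 2.3 ug/mL to 11 ug/mL. This estimate means a step of a 1.3-fold higher number from compound 2 to compound 4 (0.12 log units; within the scatter).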

Compound 4, half-maximal inhibitory concentration: 3.35 ug/mL
Compound 4: middle estimate off by 1.5-fold (0.17 log units), on the high side, within the range that was stated.
By their numbers in this assay, from the lowest: compounds 4, 2, 1 and 3 (each within the scatter of the next).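

In this assay, replacing aminoamino with (cyanomethyl)sulfanyl on this aromatic carbon gives a 1.1-fold lower number from compound 2 to compound 4 (0.05 log units; within the scatter). The earlier step from compound 2 to compound 3 kept a nitrogen on this carbon and changed only what lay beyond it, whereas here that nitrogen gives way to sulfur, both hydrogen-bond donors leave, and the group grows, yet the read-out still does not shift beyond the scatter. No measurement shown explains why so large a change in the group leaves the number within the scatter.

Both steps read at this position stay within the scatter, so no group shown here yet marks out what this position can or cannot carry. From the compounds shown here alone, whether a carboxylic acid in place of the nitrile, or a longer chain on the sulfur, would move the number beyond the scatter remains open.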